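A Second Hydroxy Group and Its Effect on Solubility

A few compounds are considered here, and "the series" means these few. Any claim that something is new, unique, unknown or untested is made for them only; others in the source may bear on it.

Of the compounds shown here, three built on the same shared core have been measured in a physicochemical assay for solubility, using the shake flask method, with a stated time of 12 h; on this read-out lower numbers stand for lower solubility and higher numbers for higher solubility. Compound 1 `O=C(/C=C/c1cccc(O)c1O)CC(=O)/C=C/c1cccc(O)c1O` gives 5300 nM. Compound 2 `O=C(/C=C/c1ccccc1O)CC(=O)/C=C/c1cccc(O)c1O` gives 11000 nM in this assay. Compound 3 `O=C(/C=C/c1cccc(O)c1)CC(=O)/C=C/c1cc(O)ccc1O` gives 5800 nM in this assay, a value that lies within the usual scatter of both compound 1 and compound 2.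

Compound 1 and compound 2 differ in a single place: hydroxy in place of hydrogen on an aromatic carbon. That change brought a 2.1-fold lower number from compound 2 to compound 1 (0.32 log units; beyond the scatter), a modest step toward lower solubility.

Compound 4 `O=C(/C=C/c1cc(O)ccc1O)CC(=O)/C=C/c1cc(O)ccc1O` has not yet been measured in this assay. It arises from compound 3 by the same kind of change: hydroxy in place of hydrogen on an aromatic carbon. The surroundings of the place are not identical, however: in compound 1 the new hydroxy sits ortho to a hydroxy group and meta to a large group, whereas in compound 4 it sits ortho to a large group and para to a hydroxy group. The cores of compound 3 and compound 2 also differ, but that difference is not broken down here.

Among the compounds with values here, with only one earlier example to go on, compound 4 is expected to show a 1.7-fold lower number from compound 3 to compound 4 (0.22 log units; within the scatter), a step of about the same size and direction as before, because the matching change gave a 2.1-fold lower number from compound 2 to compound 1 (0.32 log units; beyond the scatter). Compound 4 is therefore estimated at 3500 nM, with a likely range from 1500 nM to 8000 nM.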

Compound 4, solubility: 5000 nM
Compound 4: middle estimate off by 1.4-fold (0.15 log units), on the low side; the range from low to high includes it.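

Adding the hydroxy group to compound 3, which turns a 3-hydroxyphenyl into a 2,5-dihydroxyphenyl, gives a 1.2-fold lower number from compound 3 to compound 4 (0.06 log units; within the scatter) in this assay, so on this core the change cannot be told apart from the ordinary spread of repeat measurements, whereas the matching change on the other core gave a 2.1-fold lower number from compound 2 to compound 1 (0.32 log units; beyond the scatter) and stood clear of that spread. This shows that the clear step seen on one core did not reappear as a clear step on the other, but it does not show that the two cores truly respond differently, since each step rests on a single pair of compounds and the new hydroxy in compound 4 also sits in its own setting, ortho to a large group and para to a hydroxy group, so the core and the position cannot be separated here. Nothing in the available data explains either step.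

All the groups added to the aromatic rings in these compounds are hydroxy groups, which leaves open how an amine, a methoxy group or a carboxylic acid at the same place would read in this assay. Also open, going by these compounds, is whether a hydroxy group added at this place on a third core would track either of the two steps seen so far.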